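Swapping the amide aryl group toward a nitrile

The compounds below may be only part of what the source reports. "The series", "measured", "known", "first", "only" and "open" are said of these compounds alone.

Three measured compounds share one core, the anilide aryl group being the only place that varies. Compound 1 `COc1ccccc1C(=O)Nc1cccc(-c2oc3cc(-c4ccc(F)cc4)ccc3c(=O)c2O)c1` gives 6370 nM in a functional assay on GTL 16 cells for antiproliferative activity against GTL 16 cell line (Homo sapiens), read by CCK-8 assay, with a stated time of 72 h; on this read-out lower numbers stand for stronger inhibition and higher numbers for weaker inhibition; compound 2 `Cc1ccccc1C(=O)Nc1cccc(-c2oc3cc(-c4ccc(F)cc4)ccc3c(=O)c2O)c1` gives 24800 nM; compound 3 `COc1ccc(C(=O)Nc2cccc(-c3oc4cc(-c5ccc(F)cc5)ccc4c(=O)c3O)c2)c(F)c1` gives 15300 nM, the second highest of the three, with one neighbouring step within the scatter (a 1.6-fold lower number from compound 2 to compound 3 (0.21 log units; within the scatter)) and the other beyond it (a 2.4-fold higher number from compound 1 to compound 3 (0.38 log units; beyond the scatter)). Compound 4 `N#Cc1ccc(C(=O)Nc2cccc(-c3oc4cc(-c5ccc(F)cc5)ccc4c(=O)c3O)c2)cc1` carries the change (4-cyanophenyl in place of 2-fluoro-4-methoxyphenyl on a carbonyl carbon). Both recorded steps on this carbonyl carbon were modest, so a modest shift is expected for compound 4 in this assay, with no clear direction. The estimate for compound 4 is 15000 nM, range 5000 nM to 45000 nM, meaning a 1.0-fold lower number from compound 3 to compound 4 (0.01 log units; within the scatter).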

Compound 4, half-maximal inhibitory concentration: 31800 nM
Beside the measured number, compound 4's estimate is 2.1-fold (0.33 log units) below it; the measured number falls inside the stated range.
By their numbers in this assay, from the lowest: compound 1; then compounds 3, 2 and 4 (each within the scatter of the next, the first and the last beyond it).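

In this assay, 4-cyanophenyl on this carbonyl carbon gives a higher number than either methoxy-bearing aryl group, with a 2.1-fold higher number from compound 3 to compound 4 (0.32 log units; beyond the scatter) and a 5.0-fold higher number from compound 1 to compound 4 (0.70 log units; beyond the scatter), so the nitrile brings no gain over them. The 2-methylphenyl group cannot be separated from it, with a 1.3-fold higher number from compound 2 to compound 4 (0.11 log units; within the scatter). No evidence here accounts for these shifts.

From the compounds shown here alone, it remains open whether 2-cyanophenyl would behave like 4-cyanophenyl. Also open, going by these compounds, is whether an aryl group carrying an amine or a carboxylic acid would give a lower number than compound 1.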